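The source may hold more compounds than are shown below. What is called first, only, known or untested is meant among the compounds shown, and "the series" means these compounds.

In an ADME assay on NIH3T3 cells (Homo sapiens) for cytotoxicity, read by sulforhodamine B assay, with a stated time of 48 h (a higher number here means a weaker inhibitor, a lower number a stronger inhibitor), compound 1, `CC(=O)OC[C@H]1O[C@@H](n2cc(CN3C(=O)/C(=C/c4ccc(C)cc4)c4ccccc43)nn2)[C@H](OC(C)=O)[C@@H](OC(C)=O)[C@@H]1OC(C)=O`, gives 73300 nM, and compound 2, `CC(=O)OC[C@H]1O[C@@H](n2cc(CN3C(=O)/C(=C/C=C/c4ccccc4)c4ccccc43)nn2)[C@H](OC(C)=O)[C@@H](OC(C)=O)[C@@H]1OC(C)=O`, gives 12300 nM. Among the compounds with values here, the one step between them, a 6.0-fold lower number from compound 1 to compound 2 (0.78 log units; beyond the scatter), is the only comparison available. Within the data shown here, compound 2 therefore has the lowest of the two numbers in this assay, with compound 1 as its only neighbour at a higher number.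

Compound 3, `CC(=O)OC[C@H]1O[C@@H](n2cc(CN3C(=O)/C(=C/c4cccs4)c4ccccc43)nn2)[C@H](OC(C)=O)[C@@H](OC(C)=O)[C@@H]1OC(C)=O`, is the next compound. Its difference from compound 2 is thiophen-2-yl in place of 2-phenylethenyl on a double-bonded chain carbon bound to a double-bonded ring carbon. The measured step from compound 1 to compound 2 bears on this change only loosely: it shows that replacing a single ring bound directly at that position by the longer 2-phenylethenyl chain gave a lower number, while compound 3 returns to a single ring bound directly at that position, now with one hetero atom. Because a 6.0-fold lower number from compound 1 to compound 2 (0.78 log units; beyond the scatter) went downward on lengthening the group, the expectation is that shortening it again moves the number back upward, though to an extent the data cannot fix. For compound 3 the estimated step is a 3.3-fold higher number from compound 2 to compound 3 (0.51 log units; beyond the scatter). Compound 3 is therefore expected to give 40000 nM, with a range from 15000 nM to 100000 nM.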

Compound 3, half-maximal inhibitory concentration: 48100 nM
The estimate for compound 3 lay 1.2-fold (0.08 log units) below the measured number; the measured number falls inside the stated range.
By their numbers in this assay, from the lowest: compound 2; then compounds 3 and 1 (each within the scatter of the next).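

In this assay, thiophen-2-yl in place of 2-phenylethenyl brings a 3.9-fold higher number from compound 2 to compound 3 (0.59 log units; beyond the scatter), so the lower number of compound 2 does not carry over to this five-membered aromatic ring bound directly at the double-bonded chain carbon. Set against 4-methylphenyl, the same group gives a 1.5-fold lower number from compound 1 to compound 3 (0.18 log units; within the scatter), which leaves the six-membered and the five-membered ring indistinguishable here, and among these three compounds only 2-phenylethenyl stands apart at this position. No measurement shown offers a reason for this separation.

The compounds shown leave open whether the separation of compound 2 goes with the double bond of its 2-phenylethenyl group, with the phenyl ring at the end of that group, or with the two together, and a saturated 2-phenylethyl chain or an unsubstituted phenyl ring at the same place would bear on that question. They also leave open how this position would respond to a group carrying an amine or a carboxylic acid, since all three groups here are built only from aromatic rings and, in compound 2, a double bond.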